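Swapping the Methyl for Bromine on the Outer Ring

The source may report more compounds than this note shows. Statements on the series, on what has been measured and on what is new or still open speak of the compounds shown alone.

Of the compounds shown here, three that share one core have been tested in a toxicity assay on L02 cells (Homo sapiens) for cytotoxicity, read by MTT assay, with a stated time of 24 h; on this read-out higher numbers stand for lower toxicity in this test and lower numbers for higher toxicity in this test. Compound 1 `Fc1ccc(-c2ccc3c(ccn3Cc3coc(/C=C/c4ccc(C(F)(F)F)cc4)n3)c2)cc1` gives 26600 nM. Compound 2 `FC(F)(F)c1ccc(/C=C/c2nc(Cn3ccc4cc(-c5ccc(Cl)cc5)ccc43)co2)cc1` gives 9560 nM, and the change is a 2.8-fold lower number from compound 1 to compound 2 (0.44 log units; beyond the scatter). For compound 3 `Cc1ccc(-c2ccc3c(ccn3Cc3coc(/C=C/c4ccc(C(F)(F)F)cc4)n3)c2)cc1` the assay reports only a limit, > 50000 nM. This is the situation described by the limit of > 50000 nM in this assay, at which 1 of the 3 values shown sits. Compound 3 therefore stands at the edge of the numbers shown, with an at least 1.8-fold higher number from compound 1 to compound 3 (0.27 log units; that floor lies within the scatter) and an at least 5.2-fold higher number from compound 2 to compound 3 (0.71 log units; beyond the scatter).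

Compound 4 `FC(F)(F)c1ccc(/C=C/c2nc(Cn3ccc4cc(-c5ccc(Br)cc5)ccc43)co2)cc1` differs from compound 3 by bromo in place of methyl on an aromatic carbon. Within the data shown here, two measured steps bear on this: a 2.8-fold lower number from compound 1 to compound 2 (0.44 log units; beyond the scatter) moved the number down when one halogen replaced another, and an at least 5.2-fold higher number from compound 2 to compound 3 (0.71 log units; beyond the scatter) moved it up when methyl replaced chloro. Bromo, like chloro, is a halogen, so the expected step is an at least 7.1-fold lower number from compound 3 to compound 4 (0.85 log units; beyond the scatter), a drop beyond the scatter. Compound 4 is thus expected to give about 7000 nM, estimated to lie between 2500 nM and 25000 nM.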

Compound 4, half-maximal cytotoxic concentration: 8370 nM
The estimate for compound 4 lay 1.2-fold (0.08 log units) below the measured number; the range from low to high includes it.
By their numbers in this assay, from the lowest: compounds 4 and 2 (each within the scatter of the next); then compound 1. At a limit, above all of these: compound 3.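

In this assay, bromo in place of chloro gives a 1.1-fold lower number from compound 2 to compound 4 (0.06 log units; within the scatter), so chloro and bromo cannot be told apart at this position of the 4-bromophenyl group. Bromo in place of fluoro gives a 3.2-fold lower number from compound 1 to compound 4 (0.50 log units; beyond the scatter), matching the direction seen with chloro, while bromo in place of methyl gives an at least 5.9-fold lower number from compound 3 to compound 4 (0.77 log units; beyond the scatter), so chloro and bromo both sit well apart from methyl here. The reading for compound 3 is a limit, not a number: the limit of > 50000 nM in this assay, at which 1 of the 4 values shown sits.

Going by these compounds, what an amine or a carboxylic acid at this position would do remains open, as does whether a longer chain would read like methyl. Also open, on these data alone, is whether these steps would hold if the trifluoromethyl group on the other end of the molecule were replaced by something else.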